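The source may report more compounds than this note shows. Statements on the series, on what has been measured and on what is new or still open speak of the compounds shown alone.

Notes on the series in an ADME assay on L02 cells (Homo sapiens) for cytotoxicity, read by MTT assay, with a stated time of 24 h; a lower number here means that less compound is tolerated, a higher number that more compound is tolerated. Compound 1 `Cc1ccccc1-n1cc(-c2ccccc2NS(=O)(=O)c2c[nH]c(=O)[nH]c2=O)nn1` gives 56600 nM in this assay. Compound 2 `O=c1[nH]cc(S(=O)(=O)Nc2ccccc2-c2cn(-c3cccc(F)c3)nn2)c(=O)[nH]1` is reported in this assay only as "not toxic" (no number reported), without a single number. Compound 3 `O=c1[nH]cc(S(=O)(=O)Nc2ccccc2-c2cn(-c3ccc(F)cc3)nn2)c(=O)[nH]1` likewise stands in this assay at "not toxic" (no number reported), again with no number attached, so its position against compound 1 cannot be put in figures. Compound 4 `O=c1[nH]cc(S(=O)(=O)Nc2ccccc2-c2cn(-c3cccc(Cl)c3)nn2)c(=O)[nH]1` differs from compound 3 in one place: 3-chlorophenyl in place of 4-fluorophenyl on an aromatic nitrogen. Within the data shown here, no step between measured compounds covers this change, so no shift beyond the usual scatter is expected in either direction of this assay, and the outcome for compound 4 may again be reported without a number. Compound 4 is therefore estimated in this assay at 80000 nM, within a range of 30000 nM to 300000 nM.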

Compound 4, half-maximal cytotoxic concentration: > 100000 nM
Compound 4: a limit, no number; the forecaster's own chance of this, stated with the estimate: 65%; middle value at least 1.2-fold (0.09 log units) from the limit.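

In this assay compound 4 stands at > 100000 nM as a limit, not a number. Among these compounds, the change to 3-chlorophenyl in place of 2-methylphenyl on the aromatic nitrogen gives an at least 1.7-fold higher number from compound 1 to compound 4 (0.24 log units; that floor lies within the scatter) as the first readable step at this position, with no sign of less compound being tolerated. On these data alone, its full size stays open: the limit of > 100000 nM in this assay, at which 1 of the 4 values shown sits.

Steps to compound 2 and compound 3 cannot be read. Also open, as far as these compounds go, is where a phenyl bearing an amine or a carboxylic acid at this place would stand in this assay.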